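Notes on compound 3: 4-chlorophenyl in place of 3-fluorophenyl

The source may report more compounds than this note shows. Statements on the series, on what has been measured and on what is new or still open speak of the compounds shown alone.

Of the compounds shown here, two have numbers so far. Compound 1 `Nc1ccccc1NC(=O)c1ccc(CSc2cccc(F)c2)cc1` gives 37.7% in a functional assay on A-375 cells (Homo sapiens) for inhibition, read by CCK-8 assay, with a stated time of 72 h, tested at 2 uM; a lower number here means less inhibition of growth, a higher number more inhibition of growth at the concentration tested. Compound 2 `CC(C)(C)c1ccc(SCc2ccc(/C=C/C(=O)Nc3ccccc3N)cc2)cc1` gives 38.4% in this assay. Compound 1 stands lowest of the two numbers, but the nearest number, that of compound 2, lies within the scatter of repeated measurements, so the two values show no real difference between these compounds.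

Compound 3 `Nc1ccccc1NC(=O)c1ccc(CSc2ccc(Cl)cc2)cc1` has not yet been measured in this assay. Against compound 1 it differs in one place: 4-chlorophenyl in place of 3-fluorophenyl on a sulfur. The rest of compound 1, including the amide portion and the shared core, is kept. Within the data shown here, no step between two measured compounds covers a change of this kind, so nothing measured tells how large such a step is. The expected step of a number 2.3 percentage points higher from compound 1 to compound 3 (within the scatter) is small, not beyond the scatter, with at most a slight rise. For compound 3 the estimated value in this assay is 40%, expected to fall between 26% and 54%.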

Compound 3, percent growth inhibition at one concentration: 25.3%
Estimate against measurement, compound 3: 14.7 percentage points above, and the stated range ends above it.
By their numbers in this assay, from the lowest: compound 3; then compounds 1 and 2 (each within the scatter of the next).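

In this assay, among these compounds, replacing 3-fluorophenyl with 4-chlorophenyl on a sulfur gives a number 12.4 percentage points lower from compound 1 to compound 3 (beyond the scatter), the first step that can be read at a single place. The aryl group on the sulfur therefore matters to this read-out, even though the two groups match in heavy-atom count, ring type, hydrogen-bond donors and acceptors, and net charge; with the rest of compound 1 kept, the exchange alone accounts for the lower number. No measurement at hand bears on the reason for this fall.

The two groups differ at once in the halogen and in its place on the ring, and the compounds shown do not separate these two changes, so it remains open whether one of them or their combination carries the step. Also open, from the compounds shown here alone, is how this position would read in this assay with unsubstituted phenyl, with an amine or a carboxylic acid on the ring, or with a longer chain in place of the aryl group on the sulfur.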